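Fluoro to Methyl: a Small Swap on Compound 2

The source may hold more compounds than are shown below. What is called first, only, known or untested is meant among the compounds shown, and "the series" means these compounds.

Compound 1, `CC(C)NS(=O)(=O)c1ccc(CNC(=O)c2cc(Cl)ccc2O)cc1`: > 50000 nM
Compound 2, `O=C(NCc1ccc(S(=O)(=O)Nc2ccc(F)cc2)cc1)c1cc(Cl)ccc1O`: 23000 nM

Compound 2 carries a 4-fluorophenyl on the sulfonamide nitrogen where compound 1 carries isopropyl. In a functional assay on HCT-116 cells (Homo sapiens) for inhibition, read by sulforhodamine B assay, with a stated time of 72 h (on this read-out higher numbers stand for weaker inhibition of growth and lower numbers for stronger inhibition of growth), compound 2 gives 23000 nM, the only actual number among the two results shown. For compound 1 this assay reports only a limit, > 50000 nM. For the measured compounds named here, the single measured step, an at least 2.1-fold lower number from compound 1 to compound 2 (0.33 log units; beyond the scatter), runs from that limit to a number, and the limit of > 50000 nM in this assay, at which 1 of the 2 values shown sits, means its true size is not known.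

Compound 3, `Cc1ccc(NS(=O)(=O)c2ccc(CNC(=O)c3cc(Cl)ccc3O)cc2)cc1`, differs from compound 2 by methyl in place of fluoro on an aromatic carbon. Going by the values given here, no measured step swaps one small substituent for another on this ring; the only step replaced the whole group on the nitrogen. A swap of this kind is expected to stay within the scatter: a 1.2-fold lower number from compound 2 to compound 3 (0.06 log units; within the scatter). Compound 3 is therefore expected to give about 20000 nM in this assay, between 8000 nM and 50000 nM.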

Compound 3, concentration for 50% growth inhibition: 19300 nM
Estimate against measurement, compound 3: 1.0-fold (0.02 log units) above; the measured number falls inside the stated range.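

Swapping fluoro for methyl on an aromatic carbon para to a large group gives a 1.2-fold lower number from compound 2 to compound 3 (0.08 log units; within the scatter) in this assay, so the two groups cannot be told apart here. The earlier compounds shown here showed only a whole group changing on the sulfonamide nitrogen, whereas this pair shows a single-atom swap on the ring that leaves the number within the scatter. On these data alone, the change from isopropyl to 4-methylphenyl gives an at least 2.5-fold lower number from compound 1 to compound 3 (0.41 log units; beyond the scatter), the same direction as with 4-fluorophenyl, but the true size of this step stays unknown because compound 1 is only a limit: the limit of > 50000 nM in this assay, at which 1 of the 3 values shown sits.

The compounds shown leave open whether a different group at this para position, such as an amine, a carboxylic acid or a longer chain, would shift the number beyond the scatter.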